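Piperidinylcarbonyl in Place of Acetyl on the Shared Core

The compounds below may be only part of what the source reports. "The series", "measured", "known", "first", "only" and "open" are said of these compounds alone.

Compound 1 `CC(=O)N1CCc2nc(C#Cc3ccccc3)sc2C1` — > 10000 nM
Compound 2 `O=S(=O)(N1CCCCC1)N1CCc2nc(C#Cc3ccccc3)sc2C1` — > 10000 nM

In an assay on HEK293 cells for positive allosteric modulation of metabotropic glutamate receptor 5 (Homo sapiens), read by FLIPR, with a stated time of 1 h (on this read-out lower numbers stand for an effect already at smaller amounts and higher numbers for an effect only at larger amounts of compound), compound 1 gives > 10000 nM, which is a limit of the assay and not a number. Compound 2 gives > 10000 nM in this assay, likewise a limit. Both values sit at the limit of > 10000 nM in this assay, at which 2 of the 2 values shown sit. Compound 3 `O=C(N1CCCCC1)N1CCc2nc(C#Cc3ccccc3)sc2C1` differs from compound 1 in one place: piperidin-1-yl in place of methyl on a carbonyl carbon. For the measured compounds named here, with only limits available, no measured step can be drawn from these data. The step is expected to be a step that the limit leaves unreadable from compound 1 to compound 3, nothing beyond the scatter. Compound 3 is estimated at 15000 nM, between 3000 nM and 60000 nM.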

Compound 3, half-maximal effective concentration: 75 nM
Beside the measured number, compound 3's estimate is 200-fold (2.30 log units) above it; the whole stated range lies above it.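

In this assay, for the compounds shown here, the change from acetyl to (piperidin-1-yl)carbonyl gives an at least 130-fold lower number from compound 1 to compound 3 (2.12 log units; beyond the scatter) and, with compound 3, the first number on the shared core that is not a limit. Compound 2 carries piperidin-1-yl on a sulfonyl instead of the carbonyl, and its > 10000 nM is a limit of the assay, so this ring alone does not bring a measurable value. The step has no upper bound, since compound 1 also stands at a limit: the limit of > 10000 nM in this assay, at which 2 of the 3 values shown sit.

The compounds shown leave open whether pyrrolidin-1-yl, morpholin-4-yl or an open-chain diethylamino group on this carbonyl carbon would also give a measurable value.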